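The source may hold more compounds than are shown below. What is called first, only, known or untested is meant among the compounds shown, and "the series" means these compounds.

Two compounds sharing one core have been examined in a physicochemical assay for solubility, using the shake flask method, measured as kinetic solubility, with a stated time of 20 h, at pH 2; a higher number here means a more soluble compound, a lower number a less soluble compound. Compound 1 `Fc1ccc(Nc2cc3[nH]c(-c4cccc(C(F)(F)F)c4)nc3cn2)nc1` carries a fluoro on an aromatic carbon, and in this assay compound 1 gives only a limit of the assay, < 5000 nM, rather than a number. Compound 2 `CN1CCN(c2ccc(Nc3cc4[nH]c(-c5cccc(C(F)(F)F)c5)nc4cn3)nc2)CC1` carries a 4-methylpiperazin-1-yl in that place, and in this assay compound 2 gives 190000 nM. Among the compounds with values here, the single measured step is an at least 38-fold higher number from compound 1 to compound 2 (1.57 log units; beyond the scatter). Within the data shown here, compound 2 therefore stands as the holder of the only number so far, the other result being (the limit of < 5000 nM in this assay, at which 1 of the 2 values shown sits).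

Compound 3 `FC(F)(F)c1cccc(-c2nc3cnc(Nc4ccc(-c5nnn[nH]5)cn4)cc3[nH]2)c1` differs from compound 2 by 1H-tetrazol-5-yl in place of 4-methylpiperazin-1-yl on an aromatic carbon. This change takes away the very group whose arrival brought the large rise of an at least 38-fold higher number from compound 1 to compound 2 (1.57 log units; beyond the scatter), so a large fall in this assay on going from compound 2 is expected, although the tetrazole itself has no measured counterpart among these compounds. Compound 3 is accordingly expected to give about 8000 nM in this assay, within a range from 2000 nM to 40000 nM. The expected step is a 24-fold lower number from compound 2 to compound 3 (1.38 log units; beyond the scatter).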

Compound 3, solubility: < 5000 nM
Compound 3 ended at the assay's limit (the forecaster's own chance of this, stated with the estimate: 45%); at least 1.6-fold (0.20 log units) between middle value and limit.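

With 1H-tetrazol-5-yl on this aromatic carbon, the high number seen with 4-methylpiperazin-1-yl in this assay is not kept: the exchange gives an at least 38-fold lower number from compound 2 to compound 3 (1.57 log units; beyond the scatter). Compound 3 gives only a limit of the assay, < 5000 nM, and not a number. Among the three compounds, therefore, the high number belongs to the compound with 4-methylpiperazin-1-yl and does not follow from replacing fluoro with just any larger group, since a ring with a hydrogen-bond donor and a higher count of hydrogen-bond acceptors also leaves the result at the limit shared by compound 1 and compound 3: the limit of < 5000 nM in this assay, at which 2 of the 3 values shown sit.

From the compounds shown here alone, the two limits cannot be read against each other, so whether compound 3 lies higher than, lower than or level with compound 1 stays unknown. Going by these compounds, it also remains open whether the result in this assay depends on the whole 4-methylpiperazin-1-yl ring or would be reached with a simple open-chain amine at this position, and whether a carboxylic acid in place of the 1H-tetrazol-5-yl would stay at the limit or give a number.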